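Swapping bromo for acetyl in compound 3

The source may report more compounds than this note shows. Statements on the series, on what has been measured and on what is new or still open speak of the compounds shown alone.

Values in a functional assay on A549 cells (Homo sapiens) for antiproliferative activity, read by MTT assay; on this read-out higher numbers stand for weaker inhibition and lower numbers for stronger inhibition:
- Compound 1 `CC1(C)CCc2cc(C(=O)/C=C/c3ccc(OCc4cn(-c5ccc(Br)cc5)nn4)cc3)c(O)cc2O1`: 80000 nM
- Compound 2 `Cc1ccc(-n2cc(COc3ccc(/C=C/C(=O)c4cc5c(cc4O)OC(C)(C)CC5)cc3)nn2)cc1Br`: 125000 nM
- Compound 3 `CC1(C)CCc2c(ccc(C(=O)/C=C/c3ccc(OCc4cn(-c5ccc(Br)cc5)nn4)cc3)c2O)O1`: 129000 nM

These three numbers lie within the usual scatter of one another, so compound 3 stands level with compound 1 and compound 2, and no order among them can be read.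

Compound 4 `CC(=O)c1ccc(-n2cc(COc3ccc(/C=C/C(=O)c4ccc5c(c4O)CCC(C)(C)O5)cc3)nn2)cc1` keeps the shared core of compound 3 and alters one group: acetyl in place of bromo on an aromatic carbon. Put simply, this is acetyl in place of bromo on an aromatic carbon, or 4-bromophenyl to 4-acetylphenyl.

Among the measured compounds shown here, only one measured step touches this same aryl group: a 1.6-fold higher number from compound 1 to compound 2 (0.19 log units; within the scatter). There, 3-bromo-4-methylphenyl takes the place of 4-bromophenyl on an aromatic nitrogen, and the step stays within the scatter. For the measured compounds named here, no measured compound carries an acetyl, so this evidence is thin. On what is available, no step beyond the scatter is expected in this assay, and no direction can be given.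

The expected step is a 1.3-fold lower number from compound 3 to compound 4 (0.11 log units; within the scatter).

For compound 4 the estimated value is 100000 nM, with an expected range from 35000 nM to 250000 nM.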

Compound 4, half-maximal inhibitory concentration: 149000 nM
The estimate for compound 4 lay 1.5-fold (0.17 log units) below the measured number; the range from low to high includes it.
By their numbers in this assay, from the lowest: compounds 1, 2, 3 and 4 (each within the scatter of the next).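

In this assay, the step is a 1.2-fold higher number from compound 3 to compound 4 (0.06 log units; within the scatter), so on an aromatic carbon para to a large group, acetyl and bromo stand level. This is the first compound shown without a bromo on this aryl ring, and acetyl brings a hydrogen-bond acceptor and a double bond outside aromatic rings, neither of which bromo has, yet the number does not move beyond the scatter. Nothing measured here explains this result.

Among the compounds shown here, still open is whether any group at this same place can shift the number beyond the scatter, for example an amine, a carboxylic acid or a longer chain, since bromo and acetyl are the only two groups compared here as a single swap at this place. On these data alone, it is also open whether acetyl would stand level with bromo on the core of compound 1 as it does on the core of compound 3, and so whether this reading holds beyond a single pair of compounds.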